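This account rests on a few compounds, and the source may have more. Where it says the series, first, only, none or still open, it means among the compounds named here.

Working notes on the series. The shared core is that of compound 1 `Cc1cccc(CNc2ncnc3c2ncn3[C@@H]2O[C@H](CO)[C@@H](O)[C@H]2O)c1`, with the substituted benzyl group on the amine varied. In a functional assay on G-361 cells (Homo sapiens) for antiproliferative activity, with a stated time of 72 h (on this read-out higher numbers stand for weaker inhibition and lower numbers for stronger inhibition), compound 1 gives > 166000 nM, which is a limit of the assay and not a number. Compound 2 `OC[C@H]1O[C@@H](n2cnc3c(NCc4ccc(F)cc4F)ncnc32)[C@H](O)[C@@H]1O` gives > 166000 nM in this assay, again a limit. For the measured compounds named here, compound 3 `OC[C@H]1O[C@@H](n2cnc3c(NCc4cccc(O)c4O)ncnc32)[C@H](O)[C@@H]1O` reads 16900 nM in this assay, the only value in the set that is a number. Compound 1 thus stands at the limit of > 166000 nM in this assay, at which 2 of the 3 values shown sit, and a step that the two limits leave unreadable from compound 1 to compound 2. The two readable steps, an at least 9.8-fold lower number from compound 1 to compound 3 (0.99 log units; beyond the scatter) and an at least 9.8-fold lower number from compound 2 to compound 3 (0.99 log units; beyond the scatter), belong to the 2,3-dihydroxyphenyl compound alone.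

Compound 4 `OC[C@H]1O[C@@H](n2cnc3c(NCc4cccc(C(F)(F)F)c4)ncnc32)[C@H](O)[C@@H]1O` is not yet measured. It differs from compound 1 by trifluoromethyl in place of methyl on an aromatic carbon. Going by the values given here, no measured step alters the methyl itself, so none bears directly on this change. The nearest comparison is compound 2, whose fluorinated ring also sits at the limit, with the step from compound 1 unreadable. Among the compounds with values here, nothing among the measured steps points to a step beyond the scatter in this assay for compound 4, and the expectation is that it remains at the limit. Compound 4 is therefore estimated at 166000 nM in this assay, in the range 40000 nM to 500000 nM, most likely reported as a limit only. The expected step is a number no higher from compound 1 to compound 4 (the limit leaves the size open).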

Compound 4, half-maximal inhibitory concentration: > 166000 nM
Compound 4 ended at the assay's limit; the forecaster's own chance of this, stated with the estimate: 75%; the middle value lies on the limit itself.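

Trifluoromethyl in place of methyl, on an aromatic carbon meta to a large group, leaves the compound at the limit in this assay, so this position now holds two groups, neither of which gives a number. The steps between limits, among compound 1, compound 2 and compound 4, cannot be read, and the change therefore has no measurable size in either direction. The one readable new step, an at least 9.8-fold higher number from compound 3 to compound 4 (0.99 log units; beyond the scatter), again rests on the 2,3-dihydroxyphenyl group, which remains the only group in the set to give a number, and the limit now covers most of the series: the limit of > 166000 nM in this assay, at which 3 of the 4 values shown sit.

From the compounds shown here alone, whether an amine or a carboxylic acid in place of the methyl would give a number remains open, as does whether a phenyl carrying a single hydroxyl would do so. Going by these compounds, the true values behind the limits also remain unknown, so methyl, trifluoromethyl and 2,4-difluorophenyl cannot be ranked against one another.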